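Changing the aryl group: expected cytotoxicity of compound 4

The source may hold more compounds than are shown below. What is called first, only, known or untested is meant among the compounds shown, and "the series" means these compounds.

Compound 1 `COc1ccc(/C=C\C(=O)O)c(OCc2cn(-c3ccccc3F)nn2)c1CC=C(C)C` has "not determined" (no result reported) in a functional assay on HCT-116 cells (Homo sapiens) for cytotoxicity, read by MTT assay, with a stated time of 24 h; a lower number here means a stronger inhibitor, a higher number a weaker inhibitor. In this assay compound 2 `COc1ccc(/C=C\C(=O)O)c(OCc2cn(-c3cccc(C#N)c3)nn2)c1CC=C(C)C` gives 35300 nM and compound 3 `COc1ccc(/C=C\C(=O)O)c(OCc2cn(-c3ccccc3I)nn2)c1CC=C(C)C` gives 23100 nM. Compound 3 stands at the lowest of the two numbers shown, yet the change a 1.5-fold lower number from compound 2 to compound 3 (0.18 log units; within the scatter) stays within the scatter, so the two compounds cannot be told apart. Compound 4 `COc1ccc(/C=C\C(=O)O)c(OCc2cn(-c3ccc(C#N)cc3)nn2)c1CC=C(C)C` carries 4-cyanophenyl in place of 2-iodophenyl on an aromatic nitrogen. Within the data shown here, the only measured comparison that bears on this swap is the one between compound 2 and compound 3, an exchange of one substituted phenyl for another that left the number essentially unchanged. A similar outcome is expected here, with the step of a 1.3-fold higher number from compound 3 to compound 4 (0.11 log units; within the scatter) staying within the scatter. Compound 4 is therefore estimated at 30000 nM in this assay, with a likely range from 12000 nM to 75000 nM.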

Compound 4, half-maximal inhibitory concentration: 21000 nM
Compound 4: middle estimate off by 1.4-fold (0.15 log units), on the high side; low and high end bracket the measured number.
By their numbers in this assay, from the lowest: compounds 4, 3 and 2 (each within the scatter of the next).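

Replacing 3-cyanophenyl with 4-cyanophenyl gives a 1.7-fold lower number from compound 2 to compound 4 (0.23 log units; within the scatter) in this assay, so this shift of the nitrile around the phenyl ring has no readable effect. Replacing 2-iodophenyl with 4-cyanophenyl gives a 1.1-fold lower number from compound 3 to compound 4 (0.04 log units; within the scatter), so these three substituted phenyl groups on the aromatic nitrogen cannot be told apart. No outside data help to explain this flat result.

Still open, as far as these compounds go, is whether a phenyl ring carrying an amine or a carboxylic acid, or a simple alkyl chain in place of the phenyl ring, would separate from these compounds.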